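Hexyl for Isopropyl on a Scaffold Showing No Inhibition

A few compounds are considered here, and "the series" means these few. Any claim that something is new, unique, unknown or untested is made for them only; others in the source may bear on it.

Compound 1 `CC(C)c1cn([C@H]2C[C@@H]3OP(=O)(O)OC[C@H]3O2)c(=O)[nH]c1=O`: > 500 ug/mL
Compound 2 `CCCc1cn([C@H]2C[C@H](O)[C@@H](CO)O2)c(=O)[nH]c1=O`: > 500 ug/mL

In a functional assay on Raji cells (Homo sapiens) (on this read-out lower numbers stand for stronger inhibition and higher numbers for weaker inhibition), compound 1 gives only a limit, > 500 ug/mL, not a measured number. Compound 2 likewise gives only a limit, > 500 ug/mL. Both values sit at the limit of > 500 ug/mL in this assay, at which 2 of the 2 values shown sit, so no measurable inhibition is seen for either. Compound 3 `CCCCCCc1cn([C@H]2C[C@@H]3OP(=O)(O)OC[C@H]3O2)c(=O)[nH]c1=O` differs from compound 1 by hexyl in place of isopropyl on an aromatic carbon. Within the data shown here, no step between measured compounds exists, and the step of a number no higher from compound 1 to compound 3 (the limit leaves the size open) is expected to be none beyond the scatter. Compound 3 is therefore estimated at 500 ug/mL, within 150 ug/mL to 1500 ug/mL, most likely again reported as a limit.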

Compound 3, concentration for 50% inhibition: > 500 ug/mL
Compound 3: no number, only a limit; the forecaster's own chance of this, stated with the estimate: 80%; the middle value lies on the limit itself.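

Among these compounds, compound 1 and compound 3 each give only a limit in this assay, so no step from isopropyl to hexyl can be read: the limit of > 500 ug/mL in this assay, at which 3 of the 3 values shown sit. The compounds shown leave open whether any change to the shared core would give measurable inhibition.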